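Ester for amide on a shared pyrrole-free core comparison

A few compounds are considered here, and "the series" means these few. Any claim that something is new, unique, unknown or untested is made for them only; others in the source may bear on it.

Compound 1 `CCn1c(C(=O)NCCCN(C)C)ccc1C(CC)(CC)c1ccc(OCC(O)C(C)(C)C)c(C)c1` is measured in a functional assay on MCF7 cells (Homo sapiens), read by MTT assay, with a stated time of 48 h (on this read-out lower numbers stand for stronger inhibition and higher numbers for weaker inhibition), where compound 1 gives 490 nM. Among the three measured compounds this is the second highest number: compound 2 `CC[C@@H](C)[C@H](NC(=O)c1ccc(C(CC)(CC)c2ccc(OCC(=O)C(C)(C)C)c(C)c2)n1CC)C(=O)O` gives 160 nM, a lower number than compound 1, while compound 3 `CCn1c(C(=O)N(C)CC(=O)O)ccc1C(CC)(CC)c1ccc(OCC(=O)C(C)(C)C)c(C)c1` gives 28600 nM, a far higher number than compound 1.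

Going by the values given here, the only single-change step among the measured compounds is a 180-fold higher number from compound 2 to compound 3 (2.25 log units; beyond the scatter). That step sits on the same carbonyl carbon that is altered here, and it shows that what hangs on that carbonyl can move the read-out very far.

Compound 4 `CCn1c(C(=O)OCc2ccc(F)cc2)ccc1C(CC)(CC)c1ccc(OCC(O)C(C)(C)C)c(C)c1` differs from compound 1 in one place: (4-fluorobenzyl)oxy in place of (3-(dimethylamino)propyl)amino on a carbonyl carbon. No measured compound carries an ester on this carbonyl, so the change is not bracketed by any shown step; the step from compound 2 to compound 3 shows the size that such a change can take but not its direction for this group.

Compound 4 is therefore expected to move from compound 1 by a 1.4-fold higher number from compound 1 to compound 4 (0.15 log units; within the scatter), a step whose direction is uncertain and whose range is wide. The estimate for compound 4 in this assay is 700 nM, expected to lie between 120 nM and 4500 nM.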

Compound 4, half-maximal inhibitory concentration: > 50000 nM
Compound 4: no number, only a limit; the forecaster's own chance of this, stated with the estimate: 5%; middle value at least 71-fold (1.85 log units) away from the limit.
By their numbers in this assay, from the lowest: compound 2; then compound 1; then compound 3. At a limit, above all of these: compound 4.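

In this assay compound 4 gives > 50000 nM, which is a limit of the assay and not a number. Read against compound 1, the change is an at least 100-fold higher number from compound 1 to compound 4 (2.00 log units; beyond the scatter), so on this carbonyl carbon, (4-fluorobenzyl)oxy in place of (3-(dimethylamino)propyl)amino goes with much weaker inhibition. The earlier compounds carried only amides on this carbonyl and gave one large step between two of them, a 180-fold higher number from compound 2 to compound 3 (2.25 log units; beyond the scatter), whereas compound 4 shows that a large move towards weaker inhibition also comes with an ester here, and the true size of that move remains open-ended: the limit of > 50000 nM in this assay, at which 1 of the 4 values shown sits.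

The compounds shown leave open whether the loss follows the oxygen that replaces the amide nitrogen, or the departure of the dimethylamino chain and the arrival of the 4-fluorobenzyl group, since all of these change together between compound 1 and compound 4. A 4-fluorobenzyl amide and a 3-(dimethylamino)propyl ester on the same carbonyl would separate these two parts of the change.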